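This account rests on a few compounds, and the source may have more. Where it says the series, first, only, none or still open, it means among the compounds named here.

Three compounds with a shared core have numbers in a functional assay on HeLa cells (Homo sapiens) for antiproliferative activity, read by MTT assay, with a stated time of 72 h; a lower number here means a stronger inhibitor, a higher number a weaker inhibitor. Compound 1 `CNc1nc(-c2cc(OC)c(OC)c(OC)c2)c(-c2ccc3ccccc3c2)s1` gives 128 nM and compound 2 `CNc1nc(-c2cc(OC)c(OC)c(OC)c2)c(-c2ccc(C)cc2)s1` gives 69.1 nM, two values within the usual scatter of each other. Compound 3 `CNc1nc(-c2cc(OC)c(OC)c(OC)c2)c(-c2ccc(C(F)(F)F)cc2)s1` gives 3400 nM, the highest of the three numbers, which makes it the weakest inhibitor of the set.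

Compound 4 `CNc1nc(-c2cc(OC)c(OC)c(OC)c2)c(-c2ccc(OC)cc2)s1` is still unmeasured. It differs from compound 3 by methoxy in place of trifluoromethyl on an aromatic carbon.

Going by the values given here, only one measured step bears on this place: trifluoromethyl in place of methyl gave a 49-fold higher number from compound 2 to compound 3 (1.69 log units; beyond the scatter), a large step beyond the scatter. Removing trifluoromethyl may therefore win back much of that loss, so a large step to a lower number is expected in this assay. Among the compounds with values here, the nearest guide is compound 2 at 69.1 nM, but no methoxy compound has been measured, so the range stays wide. The estimate means a 76-fold lower number from compound 3 to compound 4 (1.88 log units; beyond the scatter), an expected large improvement. For compound 4 the estimated value is 45 nM, with an expected range from 8 nM to 300 nM.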

Compound 4, half-maximal inhibitory concentration: 70.1 nM
The estimate for compound 4 lay 1.6-fold (0.19 log units) below the measured number, and the stated range covers the measured number.
By their numbers in this assay, from the lowest: compounds 2, 4 and 1 (each within the scatter of the next); then compound 3.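

In this assay, methoxy in place of trifluoromethyl gives a 49-fold lower number from compound 3 to compound 4 (1.69 log units; beyond the scatter) and so recovers the whole loss seen at this place, which shows that the loss does not apply to every replacement of methyl. Methoxy in place of methyl on the same aromatic carbon gives a 1.0-fold higher number from compound 2 to compound 4 (0.01 log units; within the scatter) and so leaves the two groups indistinguishable in this assay, even though methoxy brings in an oxygen atom. Among methyl, methoxy and trifluoromethyl at this place, only trifluoromethyl stands apart, and nothing available here explains why.

On these data alone, it remains open whether a hydroxyl group, an amine or a chlorine atom at this place would match methyl and methoxy or trifluoromethyl. As far as these compounds go, it is also open whether a longer chain such as ethoxy would keep the activity seen with methoxy.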